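A few compounds are considered here, and "the series" means these few. Any claim that something is new, unique, unknown or untested is made for them only; others in the source may bear on it.

Working notes on the series. Compound 1 `Cc1ccc(NC(=O)NC2CCN(c3ncnc4[nH]ncc34)CC2)cc1`, compound 2 `COc1ccc(NC(=O)NC2CCN(c3ncnc4[nH]ncc34)CC2)cc1` and compound 3 `O=C(Nc1cccc(Cl)c1)NC1CCN(c2ncnc3[nH]ncc23)CC1` share one core and differ only in the group on the amide-type nitrogen. In an assay on isolated protein for inhibition of serine/threonine-protein kinase PAK 1 (Homo sapiens), read by ADP-Glo, with a stated time of 40 min (a lower number here means a stronger inhibitor, a higher number a weaker inhibitor), compound 1 gives 4710 nM, compound 2 gives 6370 nM and compound 3 gives 1240 nM. Compound 3 stands lowest of the three: a 3.8-fold lower number from compound 1 to compound 3 (0.58 log units; beyond the scatter) and a 5.1-fold lower number from compound 2 to compound 3 (0.71 log units; beyond the scatter), each beyond the scatter, whereas a 1.4-fold higher number from compound 1 to compound 2 (0.13 log units; within the scatter). Compound 4 `O=C(Nc1ccc(Cl)c(Cl)c1)NC1CCN(c2ncnc3[nH]ncc23)CC1` carries the change (chloro in place of hydrogen on an aromatic carbon). Within the data shown here, no measured step is a plain hydrogen-to-chloro exchange on a ring that already bears chloro; the only steps that bear on it are the two exchanges into compound 3 quoted above, both modest and both leading to the 3-chlorophenyl. On that footing the move to the 3,4-dichlorophenyl is expected to leave the number at or somewhat beneath that of compound 3, with a 1.7-fold lower number from compound 3 to compound 4 (0.22 log units; within the scatter) in this assay as the expected step rather than a move beyond the scatter towards a higher number. Compound 4 is accordingly estimated at 750 nM in this assay, within a range from 300 nM to 2000 nM.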

Compound 4, half-maximal inhibitory concentration: 2290 nM
The estimate for compound 4 lay 3.1-fold (0.48 log units) below the measured number, outside the stated range (above it).
By their numbers in this assay, from the lowest: compounds 3 and 4 (each within the scatter of the next); then compounds 1 and 2 (each within the scatter of the next).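

In this assay, the chloro placed on the aromatic carbon ortho to a chloro group and para to a large group, which turns the 3-chlorophenyl into the 3,4-dichlorophenyl, gives a 1.8-fold higher number from compound 3 to compound 4 (0.27 log units; within the scatter), so a second chloro at this position leaves the number where the first chloro put it. The 3,4-dichlorophenyl still stands apart from the two groups without chloro, with a 2.8-fold lower number from compound 2 to compound 4 (0.44 log units; beyond the scatter) and a 2.1-fold lower number from compound 1 to compound 4 (0.31 log units; beyond the scatter), both modest, so among these four compounds the two bearing chloro on the ring both give lower numbers than the two bearing methyl or methoxy, and none goes against this. No measurement is at hand that would explain these steps.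

From the compounds shown here alone, whether a fluoro, a nitrile or a carboxylic acid on this same ring carbon would stay level with compounds 3 and 4 or fall back towards compounds 1 and 2 remains open. Also open, going by these compounds, is whether a 3,4-dichlorophenyl would hold its place against compounds 1 and 2 on a urea replaced by a plain amide.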